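The source may hold more compounds than are shown below. What is called first, only, known or untested is meant among the compounds shown, and "the series" means these compounds.

In a physicochemical assay for lipophilicity (on this read-out lower numbers stand for lower lipophilicity and higher numbers for higher lipophilicity), compound 2 `Cc1cc(C)n(-c2ccc(Cl)c(C(=O)NC(=O)Nc3nc4ccc(S(=O)(=O)CCCN5CCN(C)CC5)cc4s3)c2)n1` stands at 2.5 as the lower of two numbers, and compound 1 `CN1CCC(S(=O)(=O)c2ccc3nc(NC(=O)NC(=O)c4cc(N5CCCC5)ccc4Cl)sc3c2)CC1` stands at 3.1 as the higher one. The gap between these two compounds lies beyond the scatter. The step to compound 3 `CN1CCN(CCCS(=O)(=O)c2ccc3nc(NC(=O)NC(=O)c4cc(N5CCCC5)ccc4Cl)sc3c2)CC1` is pyrrolidin-1-yl in place of 3,5-dimethyl-1H-pyrazol-1-yl on an aromatic carbon on an aromatic carbon. Going by the values given here, no measured pair shows this change alone. Compound 1 at 3.1 also carries pyrrolidin-1-yl, which points to a modest rise in this assay rather than a fall. The estimated step is a number 0.40 log units higher from compound 2 to compound 3 (beyond the scatter) upward and of modest size. For compound 3 the estimate is 2.9 with an expected range from 2.4 to 3.4 on this scale.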

Compound 3, distribution coefficient: 3.1
Beside the measured number, compound 3's estimate is 0.20 log units below it; low and high end bracket the measured number.
By their numbers in this assay, from the lowest: compound 2; then compounds 1 and 3 (each within the scatter of the next).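

In this assay, pyrrolidin-1-yl in place of 3,5-dimethyl-1H-pyrazol-1-yl on the aromatic carbon gives a number 0.60 log units higher from compound 2 to compound 3 (beyond the scatter), a modest step now read at this one place. On the sulfonyl sulfur, 3-(4-methylpiperazin-1-yl)propyl in place of 1-methylpiperidin-4-yl gives no change at the digits printed from compound 1 to compound 3 (within the scatter), so this exchange leaves the read-out unmoved with pyrrolidin-1-yl in place. Nothing at hand accounts for either step. Still open, on these data alone, is how a morpholin-4-yl group or a carboxylic acid on that aromatic carbon would read, and whether a longer chain on the sulfonyl sulfur would also leave the number unmoved.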